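Cyano for methylsulfonyl on the pyrrolidine side chain

The source may hold more compounds than are shown below. What is called first, only, known or untested is meant among the compounds shown, and "the series" means these compounds.

Measured compounds:
compound 2, `Cc1nn([C@H](C)c2ccc(Cl)cc2Cl)c2nc(C3=CC[C@H](N4CCC[C@H]4CO)[C@H](C)C3)cnc12` — 179 nM
compound 3, `C[C@@H]1CC(c2cnc3c(C#N)nn([C@H](C)c4ccc(Cl)cc4Cl)c3n2)=CC[C@@H]1N1CCC[C@H]1C(N)=O` — 1380 nM

Compound 1, `Cc1nn([C@H](C)c2ccc(Cl)cc2Cl)c2nc(N3CC[C@H](N4CCC[C@H]4CCS(C)(=O)=O)[C@H](C)C3)cnc12`, shares its core with compounds 2 and 3 but carries a different link to the core and a 2-(2-(methylsulfonyl)ethyl)pyrrolidin-1-yl group. In an assay on CCRF-CEM cells for antagonist activity at C-C chemokine receptor type 4 (Homo sapiens), read by CellTiter-Glo, with stated times of 30 min and 60 min, in the presence of a further agent that is not named here (a higher number here means a weaker inhibitor, a lower number a stronger inhibitor), the result for compound 1 is "not determined" (no result reported), so it stands nowhere on the numbers shown; only compound 2 with 179 nM and compound 3 with 1380 nM give a sense of where this series sits, and those two differ from each other in more than one place, so only their two values can be stated.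

Compound 4, `Cc1nn([C@H](C)c2ccc(Cl)cc2Cl)c2nc(N3CC[C@H](N4CCC[C@H]4CCC#N)[C@H](C)C3)cnc12`, differs from compound 1 in one place: cyano in place of methylsulfonyl on a saturated chain carbon, two bonds along the chain from a saturated ring carbon. For the measured compounds named here, with no measured step for this change and no number for compound 1, the direction of the step cannot be read from the data, and nothing beyond the scatter is assumed in either direction. On the values of compounds 2 and 3 alone, compound 4 is expected to lie at about 350 nM, within a broad range from 60 nM to 2000 nM.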

Compound 4, half-maximal inhibitory concentration: 865 nM
Compound 4: middle estimate off by 2.5-fold (0.39 log units), on the low side; the range from low to high includes it.
By their numbers in this assay, from the lowest: compound 2; then compounds 4 and 3 (each within the scatter of the next).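

For the compounds shown here, with no number for compound 1, no step to compound 4 can be read, so in this assay compound 4 at 865 nM stands without a direct comparison. Going by these compounds, whether cyano in place of methylsulfonyl strengthens or weakens inhibition stays open. Nothing shown offers an explanation for the value of compound 4.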